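Removing a Hydroxy Group from a Piperidine Side Chain

The source may hold more compounds than are shown below. What is called first, only, known or untested is meant among the compounds shown, and "the series" means these compounds.

Of the compounds shown here, three have been measured in an assay on isolated protein for displacement of a labelled ligand from metabotropic glutamate receptor 5 (Homo sapiens), with a stated time of 60 min, tested at 1 uM; a higher number here means more inhibition at the concentration tested (going by the name of the read-out), a lower number less inhibition. Compound 1 `Cc1ccc(S(=O)(=O)c2cnc3c(F)cccc3c2N2CCC(C)CC2)cc1` gives 93%, compound 3 `Cc1ccc2ncc(S(=O)(=O)c3ccc(Cl)cc3)c(N3CCC(C)CC3)c2c1` gives 79%, and compound 2 `O=S(=O)(c1ccc(F)cc1)c1cnc2cc(Cl)ccc2c1N1CCC(CO)CC1` gives 75%. The value of compound 2 sits within the scatter of compound 3, while compound 1 stands beyond the scatter above it. Compound 4 `CC1CCN(c2c(S(=O)(=O)c3ccc(F)cc3)cnc3cc(Cl)ccc23)CC1` has not yet been measured. It differs from compound 2 in one place: hydrogen in place of hydroxy on a saturated chain carbon bound to a saturated ring carbon. Compounds 1 and 3 both carry the 4-methylpiperidin-1-yl group that enters here, and their values run from near compound 2 to well above it. For compound 4 a modest rise, or none beyond the scatter, is expected, a step of a number 6 percentage points higher from compound 2 to compound 4 (within the scatter). Compound 4 is therefore estimated at 81%, within 66% to 93%.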

Compound 4, a percentage reported as inhibition, at one concentration (the size of the read-out at that concentration, not a potency): 91%
Compound 4: the middle estimate sits 10 percentage points below what was measured; the range from low to high includes it.
By their numbers in this assay, from the lowest: compounds 2 and 3 (each within the scatter of the next); then compounds 4 and 1 (each within the scatter of the next).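

Replacing the hydroxy with hydrogen on this saturated chain carbon gives a number 16 percentage points higher from compound 2 to compound 4 (beyond the scatter) in this assay. Going by these compounds alone, the earlier compounds differed from one another in several places, so only this pair isolates the change from 4-(hydroxymethyl)piperidin-1-yl to 4-methylpiperidin-1-yl, with the rest of the molecule held constant. No measurement at hand explains this step.

Only hydroxymethyl and methyl can be compared at this position. Going by these compounds, how a methoxymethyl group, an aminomethyl group or a longer alkyl chain would read here remains open.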